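The source may report more compounds than this note shows. Statements on the series, on what has been measured and on what is new or still open speak of the compounds shown alone.

Compound 1 `Cc1ncsc1-c1ccc(CNC(=O)[C@@H]2C[C@@H](O)CN2C(=O)[C@@H](NC(=O)COCCOCCOc2ccc(Cl)cc2C(=O)Nc2ccc([N+](=O)[O-])cc2Cl)C(C)(C)C)cc1`: 2340 nM in a functional assay on PC-3 cells (Homo sapiens) for inhibition, read by WST assay, with a stated time of 3 days; on this read-out lower numbers stand for stronger inhibition and higher numbers for weaker inhibition
Compound 2 `C#CCCOc1ccc(Cl)cc1C(=O)Nc1ccc([N+](=O)[O-])cc1Cl`: > 10000 nM in this assay, a limit of the assay and not a number
Compound 3 `CC(C)(C)OC(=O)COCCOCCn1cc(CCOc2ccc(Cl)cc2C(=O)Nc2ccc([N+](=O)[O-])cc2Cl)nn1`: > 10000 nM in this assay, again a limit and not a number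

Compound 3 therefore stands at the edge of what this assay reports: for compound 3 only a limit is known, and it is not alone in this, because of the limit of > 10000 nM in this assay, at which 2 of the 3 values shown sit. Only compound 1 gives a number in this assay; compound 2 and compound 3 give limits. No step between two measured compounds is shown for any single change, so nothing measured fixes the size of the change followed here.

Compound 4 `O=C(O)COCCOCCn1cc(CCOc2ccc(Cl)cc2C(=O)Nc2ccc([N+](=O)[O-])cc2Cl)nn1` differs from compound 3 in one place: hydrogen in place of tert-butyl on an oxygen next to a carbonyl group. The change touches only the end of the chain that carries the triazole and the two ether units, leaving the core of compound 3 as it is.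

Among the compounds with values here, with no measured step to lean on, the expected step is one of no change beyond the scatter: a step that the limit leaves unreadable from compound 3 to compound 4. Compound 4 is accordingly expected to give about 15000 nM in this assay, within a range from 5000 nM to 50000 nM, and it is expected that the assay most often reports only a limit for compound 4 rather than a number.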

Compound 4, half-maximal inhibitory concentration: > 10000 nM
Compound 4: only a limit was reported; the forecaster's own chance of this, stated with the estimate: 85%; the middle value is on the limit's open side.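

Compound 4 gives > 10000 nM in this assay, a limit and not a number. No size can be read for the change from compound 3 to compound 4, because both compounds stand at the same edge of the assay: the limit of > 10000 nM in this assay, at which 3 of the 4 values shown sit. The compounds shown leave open whether the change from tert-butoxycarbonyl to carboxy alters inhibition at all.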